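Working notes: bromo in place of chloro

The compounds below may be only part of what the source reports. "The series", "measured", "known", "first", "only" and "open" are said of these compounds alone.

Values in a functional assay on B16-F10 cells (Mus musculus) for inhibition, read by MTT assay, with a stated time of 72 h; on this read-out higher numbers stand for weaker inhibition and lower numbers for stronger inhibition
- compound 1 (`CC1(C)CC(NC(=O)Nc2ccccc2Cl)c2cc(Br)ccc2O1`) gives 22000 nM
- compound 2 (`CC1(C)CC(NC(=O)Nc2ccc(Cl)cc2)c2cc(Cl)ccc2O1`) gives 32000 nM

Among the compounds with values here, compound 2 stands within the scatter of compound 1, the only other compound with a number, so these two values do not separate. Compound 3 (`CC1(C)CC(NC(=O)Nc2ccc(Cl)cc2)c2cc(Br)ccc2O1`) has not yet been measured. It follows from compound 2 by a single change, bromo in place of chloro on an aromatic carbon. Within the data shown here, no two measured compounds differ in one place only, so the series offers no measured step for this change. Compound 1 carries the bromo but also differs elsewhere, and its 22000 nM lies within the scatter of the value of compound 2. On that basis no step beyond the scatter is expected in this assay and no direction is claimed. The estimated size of a 1.2-fold lower number from compound 2 to compound 3 (0.07 log units; within the scatter) stays within the scatter. For compound 3 the expected value is 27000 nM with an estimated range from 13000 nM to 55000 nM in this assay once measured.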

Compound 3, half-maximal inhibitory concentration: 9000 nM
The estimate for compound 3 lay 3.0-fold (0.48 log units) above the measured number, and the stated range ends above it.
By their numbers in this assay, from the lowest: compound 3; then compounds 1 and 2 (each within the scatter of the next).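

In this assay, within the data shown here, bromo in place of chloro on this aromatic carbon, with the 4-chlorophenyl group held constant, gives the first single-place reading of the change (a 3.6-fold lower number from compound 2 to compound 3 (0.55 log units; beyond the scatter)), and the step lies beyond the scatter, which the pair of compound 1 and compound 2 could not show with two places changing at once. With bromo held constant, the position of the chloro on the phenyl group also registers in this assay, as 4-chlorophenyl in place of 2-chlorophenyl on the amide-type nitrogen gives a second step beyond the scatter (a 2.4-fold lower number from compound 1 to compound 3 (0.39 log units; beyond the scatter)), so the series now has one measured step at each of the two places. Both steps are readings of activity in cells only, and no measurement shown here speaks to the reason for either of them.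

On these data alone, each change rests on a single pair, so whether bromo in place of chloro gives a similar step alongside 2-chlorophenyl remains open. As far as these compounds go, how fluoro, iodo or methoxy on this aromatic carbon would compare with bromo, and how an unsubstituted phenyl on the amide-type nitrogen would compare with 4-chlorophenyl, also remains open.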